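From cyclohexyl to 4-bromophenyl in compound 4

A few compounds are considered here, and "the series" means these few. Any claim that something is new, unique, unknown or untested is made for them only; others in the source may bear on it.

Compound 1 `O=C1C(NC2CCCC2)=CC(=O)c2c1nc1n2[C@H]2OC[C@@H](O)[C@H]2OC1`, compound 2 `O=C1C=C(NC2CCCCC2)C(=O)c2c1nc1n2[C@H]2OC[C@@H](O)[C@H]2OC1` and compound 3 `O=C1C(Nc2ccc(C(F)(F)F)cc2)=CC(=O)c2c1nc1n2[C@H]2OC[C@@H](O)[C@H]2OC1` share a core and carry different groups on an amine nitrogen. In a functional assay on ECa-109 cells for inhibition, with ECa-109 cell line (Homo sapiens) as the target, read by sulforhodamine B assay (a higher number here means a weaker inhibitor, a lower number a stronger inhibitor), compound 3 gives 2250 nM. Compound 1 reads > 16000 nM, which is a limit of the assay. Compound 2 reads > 16000 nM, also a limit. Compound 2 therefore has no number of its own and stands at the limit of > 16000 nM in this assay, at which 2 of the 3 values shown sit.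

The next compound is compound 4 `O=C1C=C(Nc2ccc(Br)cc2)C(=O)c2c1nc1n2[C@H]2OC[C@@H](O)[C@H]2OC1`, and the change is 4-bromophenyl in place of cyclohexyl on an amine nitrogen. Among the measured compounds shown here, one measured step bears on it: an at least 7.1-fold lower number from compound 1 to compound 3 (0.85 log units; beyond the scatter). On these data alone, that step starts from a limit, so its full size remains open. It also transfers only by analogy, since compound 1 and compound 3 carry the amine nitrogen at a different point of the core than compound 2 and compound 4.

A step beyond the scatter towards a lower number is expected in this assay, of about the size seen from compound 1 to compound 3. The expected step is an at least 5.3-fold lower number from compound 2 to compound 4 (0.72 log units; beyond the scatter). Compound 4 is estimated at 3000 nM, with an expected range of 800 nM to 12000 nM.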

Compound 4, half-maximal inhibitory concentration: 2850 nM
Compound 4: middle estimate off by 1.1-fold (0.02 log units), on the high side; measured number inside the range.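

In this assay, 4-bromophenyl in place of cyclohexyl gives an at least 5.6-fold lower number from compound 2 to compound 4 (0.74 log units; beyond the scatter). The lower number previously carried over only by analogy now has a direct reading at the point of the core where compound 2 carries its amine nitrogen. Alongside an at least 7.1-fold lower number from compound 1 to compound 3 (0.85 log units; beyond the scatter), read at the other point of attachment, a substituted phenyl on the amine nitrogen goes with a lower number than a saturated carbon ring in both pairs, and no compound shown goes against this, though the pattern rests on these two pairs alone. On these data alone, the full size of the new step stays open because compound 2 has only a limit and no number of its own: the limit of > 16000 nM in this assay, at which 2 of the 4 values shown sit.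

The compounds shown do not tell whether the step belongs to the aromatic ring itself or to its 4-substituent, a question that plain phenyl or 4-methoxyphenyl on the same amine nitrogen would address. Also open, as far as these compounds go, is how an open-chain group such as n-butyl would read at this position, and whether 4-bromophenyl reads alike at the other point of attachment.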